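Trifluoromethoxy Replacing Trifluoromethyl on the Benzylamide Ring

The source may report more compounds than this note shows. Statements on the series, on what has been measured and on what is new or still open speak of the compounds shown alone.

Compound 2 `CC(C)[C@@H](N)C(=O)NCc1ccc(C(F)(F)F)cc1` gives 13 mg/kg in a functional assay on the whole organism (strain albino Sprague-Dawley) with Rattus norvegicus as the target, in the maximal electroshock model; on this read-out lower numbers stand for an effect already at smaller amounts and higher numbers for an effect only at larger amounts of compound. Among the compounds with values here, compound 1 `CC(C)[C@@H](N)C(=O)NCc1ccc(F)cc1` gives 21 mg/kg in this assay, so the two measured numbers sit within the scatter of each other; the only measured step is a 1.6-fold lower number from compound 1 to compound 2 (0.21 log units; within the scatter). Compound 3 `CC(C)[C@@H](N)C(=O)NCc1ccc(OC(F)(F)F)cc1` carries trifluoromethoxy in place of trifluoromethyl on an aromatic carbon. Within the data shown here, no measured step exchanges trifluoromethyl for trifluoromethoxy, so the nearest guide is that earlier fluorine-bearing change, which stayed within the scatter. The step of no change at the digits printed from compound 2 to compound 3 (within the scatter) is therefore expected to stay within the scatter as well. Compound 3 is estimated at 13 mg/kg, with a range from 6 mg/kg to 30 mg/kg.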

Compound 3, dose for half-maximal effect: 18 mg/kg
Compound 3: the middle estimate sits 1.4-fold (0.14 log units) below what was measured; low and high end bracket the measured number.
By their numbers in this assay, from the lowest: compounds 2, 3 and 1 (each within the scatter of the next).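

Swapping trifluoromethyl for the larger trifluoromethoxy on this aromatic carbon gives, in this assay, a 1.4-fold higher number from compound 2 to compound 3 (0.14 log units; within the scatter). Against the fluoro group, the same exchange gives a 1.2-fold lower number from compound 1 to compound 3 (0.07 log units; within the scatter). All three fluorine-bearing groups therefore cannot be told apart on this read-out, and adding an oxygen at this spot does not move the number beyond the scatter. No measurement on hand bears on what lies behind this result. As far as these compounds go, whether a group without fluorine, such as an amine or a carboxylic acid, would be tolerated equally well at this position stays open.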